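Swapping a nitro-bearing benzyl ether for a chlorinated one

The source may report more compounds than this note shows. Statements on the series, on what has been measured and on what is new or still open speak of the compounds shown alone.

Of the compounds shown here, three sharing one core have been tested in an ADME assay on HEL cells (Homo sapiens) for cytotoxicity, with a stated time of 3 days; a higher number here means that more compound is tolerated, a lower number that less compound is tolerated. Compound 1, with the structure `CCC1(Cc2ccccc2)OS(=O)(=O)C=C1OCc1ccc([N+](=O)[O-])cc1`, does not give a number there: in this assay compound 1 returns only the limit < 200000 nM, which is a boundary of the measurement rather than a value. That is the limit of < 200000 nM in this assay, at which 1 of the 3 values shown sits. Compound 2, with the structure `CC1(Cc2ccccc2)OS(=O)(=O)C=C1OCc1ccccc1`, gives 68000 nM in this assay. Compound 3, with the structure `CCC1(CC)OS(=O)(=O)C=C1OCc1ccccc1`, gives 200000 nM in this assay. All three therefore sit at high concentrations, meaning that large amounts of each are tolerated by the cells.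

Compound 4, with the structure `CCC1(Cc2ccccc2)OS(=O)(=O)C=C1OCc1ccccc1Cl`, has not yet been measured in this assay. It differs from compound 1 in one place: 2-chlorophenyl in place of 4-nitrophenyl on a saturated chain carbon bound to an oxygen on an unsaturated carbon. Among the compounds with values here, since compound 1 offers only a limit, no measured step is available for this change. The expectation is that compound 4 stays in the same high range as its neighbours, with a step from compound 1 that is small or none beyond the scatter, so that a step that the limit leaves unreadable from compound 1 to compound 4 is estimated to be modest. For compound 4 the estimated value in this assay is 150000 nM, with a range from 50000 nM to 300000 nM.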

Compound 4, half-maximal cytotoxic concentration: 38000 nM
Compound 4: the middle estimate sits 3.9-fold (0.60 log units) above what was measured; the measured number lies below the stated range.
By their numbers in this assay, from the lowest: compounds 4 and 2 (each within the scatter of the next); then compound 3.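

The step from compound 1 to compound 4 cannot be read, because compound 1 gives only a limit and not a number: the limit of < 200000 nM in this assay, at which 1 of the 4 values shown sits.

The compounds shown leave open whether 2-chlorophenyl in place of 4-nitrophenyl changes how much compound the cells tolerate, and by how much.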